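The source may report more compounds than this note shows. Statements on the series, on what has been measured and on what is new or still open speak of the compounds shown alone.

In a functional assay on CHO cells for agonist activity at Free fatty acid receptor 1 (Homo sapiens), read by FLIPR and calcium flux, tested at 100 nM (a lower number here means a weaker effect, a higher number a stronger effect of the compound at the concentration tested), compound 1 `Cc1nc(-c2ccccc2)sc1COc1ccc2c(c1)OCC2CC(=O)O` gives 54.8%. Compound 2 `Cc1nc(-c2cccc3ccccc23)sc1COc1ccc2c(c1)OCC2CC(=O)O` gives 8.53%, and compound 3 `Cc1ccccc1-c1nc(C)c(COc2ccc3c(c2)OCC3CC(=O)O)s1` gives 10.7%; compound 3 therefore stands second highest of the three numbers, close to compound 2 and far below compound 1. Compound 4 `Cc1cccc(-c2nc(C)c(COc3ccc4c(c3)OCC4CC(=O)O)s2)c1` differs from compound 3 in one place: 3-methylphenyl in place of 2-methylphenyl on an aromatic carbon. Within the data shown here, no measured step tests this exact change. The nearest are a number 44.1 percentage points lower from compound 1 to compound 3 (beyond the scatter) and a number 2.2 percentage points higher from compound 2 to compound 3 (within the scatter), which together show that the 2-methylphenyl group sits low, alongside compound 2. Whether a 3-methylphenyl group regains part of the response seen for compound 1 cannot be read from these steps, so only a modest rise, a number 11.3 percentage points higher from compound 3 to compound 4 (beyond the scatter), is expected, with wide uncertainty. Compound 4 is estimated at 22%, between 5% and 50%.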

Compound 4, a percentage reported as activity, at one concentration (the size of the read-out at that concentration, not a potency): 47.2%
Compound 4: middle estimate off by 25.2 percentage points, on the low side; measured number inside the range.
By their numbers in this assay, from the lowest: compounds 2 and 3 (each within the scatter of the next); then compounds 4 and 1 (each within the scatter of the next).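

Carried as 3-methylphenyl rather than 2-methylphenyl, the same methyl group gives a large step (a number 36.5 percentage points higher from compound 3 to compound 4 (beyond the scatter)), so the low number of compound 3 does not hold for every methyl-bearing phenyl at this position. The 3-methylphenyl group also stands clear of naphthalen-1-yl (a number 38.7 percentage points higher from compound 2 to compound 4 (beyond the scatter)) and remains within the scatter of the unsubstituted phenyl (a number 7.6 percentage points lower from compound 1 to compound 4 (within the scatter)). Nothing available explains why the two methylphenyl groups differ. Open, as far as these compounds go, is whether an ethyl, methoxy or chloro group in place of that methyl would keep this response.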